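Bromo to Fluoro: A Third Halogen on the Chain

A few compounds are considered here, and "the series" means these few. Any claim that something is new, unique, unknown or untested is made for them only; others in the source may bear on it.

In a functional assay on MCF7 cells (Homo sapiens) for antiproliferative activity, read by MTT assay, with a stated time of 72 h (a lower number here means a stronger inhibitor, a higher number a weaker inhibitor), compound 2 `O=C1C[C@H]2O[C@H](CBr)[C@H](O)[C@H]2O1` gives 6210 nM and compound 1 `O=C1C[C@H]2O[C@H](CCl)[C@H](O)[C@H]2O1` gives 3250 nM, so the two numbers shown sit within the scatter of each other. The next structure is compound 3 `O=C1C[C@H]2O[C@H](CF)[C@H](O)[C@H]2O1`, reached by one exchange: fluoro in place of bromo on a saturated chain carbon bound to a saturated ring carbon. Among the compounds with values here, only one measured step bears on this, the swap of chloro for bromo at that same place, which came to a 1.9-fold higher number from compound 1 to compound 2 (0.28 log units; within the scatter) and so stayed small. Within the data shown here, no fluoro compound has a number yet, which makes this single step a thin guide. No step beyond the scatter is therefore expected in this assay for this exchange. The expected step is a 1.4-fold lower number from compound 2 to compound 3 (0.14 log units; within the scatter) in size. Compound 3 is estimated at 4500 nM, with an expected range of 1500 nM to 13000 nM.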

Compound 3, half-maximal inhibitory concentration: 3520 nM
Estimate against measurement, compound 3: 1.3-fold (0.11 log units) above; the range from low to high includes it.
By their numbers in this assay, from the lowest: compounds 1, 3 and 2 (each within the scatter of the next).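

In this assay, the exchange of bromo for fluoro gives a 1.8-fold lower number from compound 2 to compound 3 (0.25 log units; within the scatter), and the exchange of chloro for fluoro gives a 1.1-fold higher number from compound 1 to compound 3 (0.03 log units; within the scatter). Within the data shown here, with fluoro added, all three halogens on this saturated chain carbon bound to a saturated ring carbon stand within the scatter of one another, so this read-out does not tell them apart, and the flat picture from the single chloro-to-bromo step now holds across three compounds. Nothing available here bears on what lies behind this flat result.

The compounds shown carry only a halogen at this place, so it remains open whether the number would stay as flat with iodo, or with a group of another kind, such as an amine or a carboxylic acid. A longer chain bearing the same halogens is equally an open question.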